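From bromo to methylsulfonyl on compound 3

This account rests on a few compounds, and the source may have more. Where it says the series, first, only, none or still open, it means among the compounds named here.

Measured in an ADME assay on MRC5 cells (Homo sapiens) for cytotoxicity, read by fluorescence, with a stated time of 72 h (on this read-out lower numbers stand for stronger inhibition and higher numbers for weaker inhibition), so far:
- Compound 1 `CC1(COc2cnc(C(F)(F)F)cn2)Cn2cc([N+](=O)[O-])nc2O1` gives > 64000 nM as a limit of the assay
- Compound 2 `O=[N+]([O-])c1cnc2n1C[C@H](COc1ccc(-c3ccc(F)cc3)nc1)O2` gives 54000 nM as its value
- Compound 3 `CC1(COc2ccc(OC(F)(F)F)cc2)Cn2cc(Br)nc2O1` gives 34000 nM as its value

In this assay compound 3 stands at 34000 nM and lies within the usual scatter of compound 2 at 54000 nM on this read-out. The value for compound 1 is a limit and not a number. Compound 4 `CC1(COc2ccc(OC(F)(F)F)cc2)Cn2cc(S(C)(=O)=O)nc2O1` has methylsulfonyl in place of bromo on an aromatic carbon and is otherwise the same as compound 3.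

Going by the values given here, no measured pair shows a change in one place, so the expectation rests on compound 3 at 34000 nM alone. A small move toward higher numbers is expected in this assay and it may not clear the scatter. The estimated step of a 1.8-fold higher number from compound 3 to compound 4 (0.25 log units; within the scatter) is therefore a modest one. The assay may also report only a limit for compound 4, like the limit of > 64000 nM in this assay, at which 1 of the 3 values shown sits, in the present set. Compound 4 is estimated at 60000 nM with 25000 nM to 130000 nM as the expected range.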

Compound 4, half-maximal inhibitory concentration: > 64000 nM
Compound 4 gave a limit, no number; the forecaster's own chance of this, stated with the estimate: 45%; at least 1.0-fold (0.02 log units) between middle value and limit.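

This is the first change in one place among the compounds shown, and it concerns the aromatic carbon of the five-membered ring that bears bromo in compound 3. In this assay, methylsulfonyl in place of bromo gives an at least 1.8-fold higher number from compound 3 to compound 4 (0.27 log units; that floor lies within the scatter), so the data show a move toward weaker inhibition of at most uncertain size, since its floor does not clear the scatter. Compound 4 ends at a limit and not at a number, and such limits now make up a larger share of the set: the limit of > 64000 nM in this assay, at which 2 of the 4 values shown sit.

The compounds shown leave open how far the true value of compound 4 lies past that limit, and so whether this step truly exceeds the scatter. They also leave open how an amine or a carboxylic acid on this same aromatic carbon would read in this assay.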